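Removing One Hydroxy Group from Compound 2

The compounds below may be only part of what the source reports. "The series", "measured", "known", "first", "only" and "open" are said of these compounds alone.

Compound 2 `O=C(/C=C/c1ccc2c(c1)B(O)OC2)c1ccc(O)c(O)c1` carries two hydroxy groups on one of its aromatic rings. In a functional assay on SK-OV-3 cells (Homo sapiens) for cytotoxicity, read by MTT assay, with a stated time of 48 h (a lower number here means a stronger inhibitor, a higher number a weaker inhibitor), compound 2 gives only a limit, > 100000 nM, so its true value is not known as a number. Its neighbour compound 1 `O=C(/C=C/c1ccc2c(c1)B(O)OC2)c1ccc(O)cc1` carries a single hydroxy group on that ring, and in this assay compound 1 gives 13000 nM. Among the compounds with values here, the only measured step between them, an at least 7.6-fold higher number from compound 1 to compound 2 (0.88 log units; beyond the scatter), shows that adding the second hydroxy weakened the compound, by at least as much as the assay could resolve (the limit of > 100000 nM in this assay, at which 1 of the 2 values shown sits).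

Compound 3 `O=C(/C=C/c1ccc2c(c1)B(O)OC2)c1cccc(O)c1` has not yet been measured. It differs from compound 2 by hydrogen in place of hydroxy on an aromatic carbon. The hydroxy that leaves is not the one that entered in the step to compound 2, so compound 3 keeps a single hydroxy on that ring, but in a different place from compound 1. As an at least 7.6-fold higher number from compound 1 to compound 2 (0.88 log units; beyond the scatter) ran in the weakening direction when a hydroxy was added, a gain is expected when one is removed, though its size is uncertain: for compound 2 only a limit is known. Compound 3 is therefore expected at 30000 nM, between 8000 nM and 150000 nM. The expected step is an at least 3.3-fold lower number from compound 2 to compound 3 (0.52 log units; beyond the scatter).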

Compound 3, half-maximal inhibitory concentration: 3800 nM
Estimate against measurement, compound 3: 7.9-fold (0.90 log units) above; the whole stated range lies above it.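

In this assay, taking away the hydroxy that stood para to a large group, while the hydroxy ortho to that place stays, gives an at least 26-fold lower number from compound 2 to compound 3 (1.42 log units; beyond the scatter), so this one position on the ring carries a large change in the cell read-out. That size is only a floor, and compound 2 stands at a limit of the assay rather than at a number: the limit of > 100000 nM in this assay, at which 1 of the 3 values shown sits.

What is new is that a single hydroxy does not count the same wherever it sits, for the change to 3-hydroxyphenyl in place of 4-hydroxyphenyl gives a 3.4-fold lower number from compound 1 to compound 3 (0.53 log units; beyond the scatter), which shows that the place of the hydroxy matters and not only the number of hydroxy groups; among these three compounds, the ring carrying both hydroxy groups is the weakest, and compound 3 is the strongest.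

None of the compounds shown has this ring without a hydroxy, so whether the remaining hydroxy of compound 3 helps at all, compared with plain hydrogen, stays open. Going by these compounds, whether a methoxy group or an amine could stand in its place and keep the same strength also stays open.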